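A few compounds are considered here, and "the series" means these few. Any claim that something is new, unique, unknown or untested is made for them only; others in the source may bear on it.

Of the compounds shown here, three built on one shared core have been tested in a functional assay on M21 cells (Homo sapiens) for antiproliferative activity, read by sulforhodamine B assay, with a stated time of 48 h; on this read-out lower numbers stand for stronger inhibition of growth and higher numbers for weaker inhibition of growth. Compound 1 `CCCCc1ccc(-c2cc(N3CCC(CNS(N)(=O)=O)CC3)ncn2)cc1` gives 47200 nM, the highest of the three numbers. Compound 2 `CC(C)(C)c1ccc(-c2cc(N3CCC(CNS(N)(=O)=O)CC3)ncn2)cc1` gives 19300 nM, and compound 3 `NS(=O)(=O)NCC1CCN(c2cc(-c3ccc(C(F)(F)F)cc3)ncn2)CC1` gives 43100 nM. The step of a 2.4-fold lower number from compound 1 to compound 2 (0.39 log units; beyond the scatter) is modest but beyond the scatter; the step of a 1.1-fold lower number from compound 1 to compound 3 (0.04 log units; within the scatter) lies within it; the step of a 2.2-fold higher number from compound 2 to compound 3 (0.35 log units; beyond the scatter) is again modest. All three of these steps alter only the group on the aromatic carbon, leaving the rest of the molecule untouched.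

Compound 4 `CCCCc1ccc(-c2cc(N3CCC(CCNS(N)(=O)=O)CC3)ncn2)cc1` differs from compound 1 in a different region: (sulfamoylamino)methyl in place of sulfamoylamino on a saturated chain carbon bound to a saturated ring carbon. For the measured compounds named here, no measured pair changes this part of the structure, so none of the three known steps bears directly on the change; they describe the aromatic substituent and nothing else. What they do show is that the series sits in a narrow band, with compound 1 close to compound 3 and not far from compound 2. Going by the values given here, with no step to inform the chain extension, the expected step of a 1.0-fold lower number from compound 1 to compound 4 (0.00 log units; within the scatter) is none beyond the scatter. Compound 4 is therefore estimated at 47000 nM in this assay, with a range from 18000 nM to 120000 nM.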

Compound 4, concentration for 50% growth inhibition: 15100 nM
Compound 4: middle estimate off by 3.1-fold (0.49 log units), on the high side, outside the stated range (below it).
By their numbers in this assay, from the lowest: compounds 4 and 2 (each within the scatter of the next); then compounds 3 and 1 (each within the scatter of the next).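

In this assay, the chain that carries the sulfamoylamino group proves to be a place where the read-out responds: 2-(sulfamoylamino)ethyl on the core of compound 4, read against (sulfamoylamino)methyl on that of compound 1, gives a 3.1-fold lower number from compound 1 to compound 4 (0.49 log units; beyond the scatter). For the compounds shown here, the earlier steps changed only the group on the aromatic carbon, so this is the first sign that a second region of the molecule can shift growth inhibition; the step is modest, like a 2.4-fold lower number from compound 1 to compound 2 (0.39 log units; beyond the scatter), but it too lies beyond the scatter. Nothing available here explains the shift, and no measurement accompanies it that could say what the added chain carbon does.

The compounds shown leave open whether a longer chain still would lower the number further or reverse the trend, and whether an amine or a carboxylic acid in place of the sulfamoylamino group at the chain end would keep any of this activity. They also leave open whether the same chain extension would give a similar step on the tert-butyl or trifluoromethyl compounds, compound 2 and compound 3, or whether its effect holds only with the butyl group of compound 1.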